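Lengthening the Sulfur Chain: What Might Compound 4 Do?

The source may hold more compounds than are shown below. What is called first, only, known or untested is meant among the compounds shown, and "the series" means these compounds.

Measured in a functional assay on NALM-6 cells (Homo sapiens); on this read-out higher numbers stand for weaker inhibition and lower numbers for stronger inhibition:
- Compound 1 `CCSC[C@H](NC(C)=O)C(=O)CCl`: 52800 nM
- Compound 2 `CCCSC[C@H](NC(C)=O)C(=O)CCl`: 6900 nM
- Compound 3 `CCCCCSC[C@H](NC(C)=O)C(=O)CCl`: 5800 nM

Compound 2, at 6900 nM, lies within the scatter of compound 3 and well under compound 1. Compound 4 `CCCCCCCSC[C@H](NC(C)=O)C(=O)CCl` carries a longer chain on the sulfur: butyl in place of hydrogen on a saturated chain carbon, three bonds along the chain from a sulfur. Among the compounds with values here, two measured steps bear on this change. The first, a 7.7-fold lower number from compound 1 to compound 2 (0.88 log units; beyond the scatter), lies beyond the scatter. The second, a 1.2-fold lower number from compound 2 to compound 3 (0.08 log units; within the scatter), lies within it and is made at the same place as the new change. This smaller step is the closer guide, so no step beyond the scatter is expected in this assay. The expected step is a 1.5-fold lower number from compound 2 to compound 4 (0.19 log units; within the scatter). For compound 4 the estimated value is 4500 nM, with an expected range of 1700 nM to 12000 nM.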

Compound 4, half-maximal inhibitory concentration: 4800 nM
Beside the measured number, compound 4's estimate is 1.1-fold (0.03 log units) below it; measured number inside the range.
By their numbers in this assay, from the lowest: compounds 4, 3 and 2 (each within the scatter of the next); then compound 1.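

Butyl in place of hydrogen gives a 1.4-fold lower number from compound 2 to compound 4 (0.16 log units; within the scatter) and the further ethyl gives a 1.2-fold lower number from compound 3 to compound 4 (0.08 log units; within the scatter) in this assay and both lie within the scatter, so compound 2, compound 3 and compound 4 cannot be told apart here. The full span shows an 11-fold lower number from compound 1 to compound 4 (1.04 log units; beyond the scatter) as a large step, yet that gain is already largely in place at compound 2, and these longer chains form a plateau. Nothing measured here gives a reason for this plateau.

On these data alone, whether a longer chain stays on the plateau, or an amine or carboxylic acid at the chain end shifts the number, remains open.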